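The source may report more compounds than this note shows. Statements on the series, on what has been measured and on what is new or still open speak of the compounds shown alone.

Working notes on the series.

Two compounds have numbers in a functional assay on Huh-7 cells (Homo sapiens) for inhibition, read by sulforhodamine B assay, with a stated time of 72 h (on this read-out lower numbers stand for stronger inhibition and higher numbers for weaker inhibition), so far. Compound 1 `CC(c1ccc(-c2ccccc2)c(F)c1)c1nnc2n1N=C(c1ccc(Cl)cc1Cl)CS2` gives 3700 nM in this assay. Compound 2 `COc1ccc2cc(C(C)c3nnc4n3N=C(c3ccc(Cl)cc3Cl)CS4)ccc2c1` gives 10700 nM in this assay. Compound 2 thus stands at the higher of the two numbers, and the gap between compound 2 and compound 1 lies beyond the usual scatter, so compound 2 is the weaker of the two measured entries.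

Compound 3 `COc1ccc2cc(C(C)c3nnc4n3N=C(c3ccc(C)cc3)CS4)ccc2c1` has not been measured. It keeps the core of compound 2 and differs in one place: 4-methylphenyl in place of 2,4-dichlorophenyl on a carbon with a double bond to nitrogen. For the measured compounds named here, no measured pair carries this change, so there is no recorded step from which its size could be read. The difference between compound 1 and compound 2 concerns a different part of the molecule and says nothing direct about this exchange.

With nothing in the series to anchor it, the expectation for the step from compound 2 to compound 3 is a modest move toward a higher number, a 1.4-fold higher number from compound 2 to compound 3 (0.15 log units; within the scatter), with wide uncertainty in both directions. Compound 3 is therefore estimated at 15000 nM in this assay, with a range from 5000 nM to 45000 nM.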

Compound 3, half-maximal inhibitory concentration: 8200 nM
Compound 3: the middle estimate sits 1.8-fold (0.26 log units) above what was measured; the measured number falls inside the stated range.
By their numbers in this assay, from the lowest: compound 1; then compounds 3 and 2 (each within the scatter of the next).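

In this assay, for the compounds shown here, the exchange of 2,4-dichlorophenyl for 4-methylphenyl on a carbon with a double bond to nitrogen gives a 1.3-fold lower number from compound 2 to compound 3 (0.12 log units; within the scatter) and so provides the first recorded step at this position. On the core of compound 2 the two aryl groups cannot be told apart in this read-out, even though the group that leaves carries 2 chlorine and the group that enters carries carbon only. This single pair therefore shows that the read-out does not depend on keeping 2,4-dichlorophenyl at this place on this core, and no measurement at hand bears on why the two groups read alike.

Still open, going by these compounds, is whether this position stays as undiscriminating when the entering group is no longer a six-membered aromatic ring of carbon only, for example when an amine, a carboxylic acid or a longer chain stands in place of 4-methylphenyl. Also open, on these data alone, is whether the same exchange would read alike on the core of compound 1, since a single pair on the core of compound 2 cannot settle that.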